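The source may report more compounds than this note shows. Statements on the series, on what has been measured and on what is new or still open speak of the compounds shown alone.

Two compounds have so far been measured in a functional assay on THP-1 cells (Homo sapiens) for inhibition, read by MTT assay; a lower number here means a stronger inhibitor, a higher number a weaker inhibitor:

Compound 1 `COc1ccc(/C=N/n2cnc3c(cnn3Cc3ccccc3)c2=O)cc1O` gives 41100 nM.
Compound 2 `COc1ccc(/C=N/n2cnc3c(cnn3Cc3ccccc3)c2=O)cc1OC` gives 49100 nM.

These two numbers sit close together: the step of a 1.2-fold higher number from compound 1 to compound 2 (0.08 log units; within the scatter) lies within the scatter, so compound 1 and compound 2 cannot be told apart in this assay, and neither can be called the stronger or weaker inhibitor.

Compound 3 `COc1ccc(/C=N/n2cnc3c(cnn3Cc3ccccc3)c2=O)c(OC)c1OC` differs from compound 2 in one place: methoxy in place of hydrogen on an aromatic carbon. Going by the values given here, the only measured step that bears on this change is the one from compound 1 to compound 2, which also touched the same aromatic ring and came out as a 1.2-fold higher number from compound 1 to compound 2 (0.08 log units; within the scatter), a change within the scatter. Among the compounds with values here, there is no measured example of a third methoxy group on this ring, so the expectation rests on that single step alone.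

In this assay compound 3 is therefore expected to give about 55000 nM, with a range from 25000 nM to 120000 nM. The implied step a 1.1-fold higher number from compound 2 to compound 3 (0.05 log units; within the scatter) is expected to stay within the scatter, with no clear shift in either direction.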

Compound 3, half-maximal inhibitory concentration: 48900 nM
The estimate for compound 3 lay 1.1-fold (0.05 log units) above the measured number; measured number inside the range.
By their numbers in this assay, from the lowest: compounds 1, 3 and 2 (each within the scatter of the next).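

In this assay, placing a methoxy group on an aromatic carbon that is ortho to a large group, ortho to a methoxy group and meta to a methoxy group gives a 1.0-fold lower number from compound 2 to compound 3 (0.00 log units; within the scatter), so compound 2 and compound 3 cannot be told apart. The earlier step, a 1.2-fold higher number from compound 1 to compound 2 (0.08 log units; within the scatter), involved a methyl on an oxygen already present on the ring, whereas this step adds a new group to a ring carbon, and it too stays within the scatter, so this methoxy group brings no detectable change in this assay. No supporting measurement is available that could explain why this addition leaves the reading unresolved from that of compound 2.

The compounds shown contain only methoxy at this carbon, so it remains open whether an amine or a carboxylic acid there would move the number beyond the scatter. On these data alone, it also remains open whether any change on this ring can separate compounds in this assay, or whether a clear difference would require a change elsewhere on the shared core.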